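The source may report more compounds than this note shows. Statements on the series, on what has been measured and on what is new or still open speak of the compounds shown alone.

Measured compounds:
compound 1, `C[Se]/C(=N\C(=O)c1cc2ccccc2s1)NC(=O)c1cc2ccccc2s1`, 61000 nM
compound 2, `CS/C(=N\C(=O)c1sccc1Cl)NC(=O)c1sccc1Cl`, 78900 nM
compound 3, `CS/C(=N\C(=O)c1cc2ccccc2s1)NC(=O)c1cc2ccccc2s1`, 66600 nM

These three compounds were tested in a functional assay on K562 cells (Homo sapiens) for cytotoxicity, read by MTT assay, with a stated time of 72 h; on this read-out lower numbers stand for stronger inhibition of growth and higher numbers for weaker inhibition of growth. Compound 1 and compound 3 share one core, and the two differ only in a group of 2 heavy atoms (1 carbon, 1 selenium; no ring) in place of a group of 2 heavy atoms (1 carbon, 1 sulfur; no ring), on a carbon with a double bond to nitrogen; the step of a 1.1-fold lower number from compound 3 to compound 1 (0.04 log units; within the scatter) lies within the scatter, so the two values show no ordering. Compound 2 stands on a different core, and the difference between the two cores is not broken down here. Its value and that of compound 3 lie within the scatter of each other, as do its value and that of compound 1.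

Compound 4, `C[Se]/C(=N\C(=O)c1sccc1Cl)NC(=O)c1sccc1Cl`, has not yet been measured. It differs from compound 2 in a group of 2 heavy atoms (1 carbon, 1 selenium; no ring) in place of a group of 2 heavy atoms (1 carbon, 1 sulfur; no ring), on a carbon with a double bond to nitrogen, the same kind of change as that between compound 3 and compound 1, made on a carbon with a double bond to nitrogen whose other neighbours are amide-type nitrogen and amide-type nitrogen in both cases. Because a 1.1-fold lower number from compound 3 to compound 1 (0.04 log units; within the scatter) lay within the scatter, the corresponding step is expected to be small as well: a 1.1-fold lower number from compound 2 to compound 4 (0.04 log units; within the scatter) is the estimate. Compound 4 is therefore expected to give about 72000 nM in this assay, most likely between 38000 nM and 135000 nM.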

Compound 4, concentration for total growth inhibition: 28500 nM
Estimate against measurement, compound 4: 2.5-fold (0.40 log units) above, outside the stated range (below it).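

In this assay, putting the selenium group in place of methylsulfanyl, on a carbon with a double bond to nitrogen, gives a 2.8-fold lower number from compound 2 to compound 4 (0.44 log units; beyond the scatter), while the same change on the other core gives a 1.1-fold lower number from compound 3 to compound 1 (0.04 log units; within the scatter). Although only the first of these steps lies beyond the scatter, the two cannot be told apart when set side by side: the same change on two cores in this assay, a 1.1-fold lower number (0.04 log units; within the scatter) from compound 3 to compound 1 and a 2.8-fold lower number (0.44 log units; beyond the scatter) from compound 2 to compound 4, 2.5-fold (0.40 log units) apart, within the scatter of two such steps. Going by these compounds alone, the series therefore does not show that the core alters the outcome of this change, nor does it show that the change carries over unaltered, since each core supplies only one matched pair.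

The compounds shown leave open how the change would behave on cores bearing other acyl groups, as only two such cores appear here. They also leave open how an amine, a methoxy group or a longer chain such as ethylsulfanyl would compare with methylsulfanyl and the selenium group on a carbon with a double bond to nitrogen.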